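Amide nitrogen substituent removal in the sulfonamide series

A few compounds are considered here, and "the series" means these few. Any claim that something is new, unique, unknown or untested is made for them only; others in the source may bear on it.

Compound 1 `O=C(N[C@@H]1CCNC1)c1cc(-c2ccc(NS(=O)(=O)c3cccc(Cl)c3Cl)cc2)nc2[nH]ncc12`: in an assay for inhibition of serine/threonine-protein kinase Sgk1 (Homo sapiens), with stated times of 30 min and 60 min, in the presence of a further agent that is not named here (a higher number here means a weaker inhibitor, a lower number a stronger inhibitor), compound 1 gives < 1 nM, which is a limit of the assay.
Compound 2 `CN1CCC(NC(=O)c2cc(-c3ccc(NS(=O)(=O)c4cccc(Cl)c4Cl)cc3)nc3[nH]ncc23)C1`: in this assay compound 2 gives < 1 nM, also a limit of the assay.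

Compound 2 stands only at a limit, with no number of its own. For the measured compounds named here, the one measured step, a step that the two limits leave unreadable from compound 1 to compound 2, cannot be read, since both ends sit at the limit of < 1 nM in this assay, at which 2 of the 2 values shown sit. Going by the values given here, no measured step touches the change now considered, which is hydrogen in place of 1-methylpyrrolidin-3-yl on an amide-type nitrogen, giving compound 3 `NC(=O)c1cc(-c2ccc(NS(=O)(=O)c3cccc(Cl)c3Cl)cc2)nc2[nH]ncc12`.

The measured pair therefore offers no direction: neither a loss nor a gain on removing the ring substituent from the amide nitrogen is shown anywhere. The expectation for compound 3 is thus unanchored and wide, and compound 3 is estimated in this assay at 3 nM, between 0.5 nM and 30 nM. The estimated step of an at least 3.0-fold higher number from compound 2 to compound 3 (0.47 log units; beyond the scatter) is expected to be a modest weakening at most, with the chance that compound 3 also reports only a limit.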

Compound 3, half-maximal inhibitory concentration: 1 nM
Estimate against measurement, compound 3: 3.0-fold (0.48 log units) above; the range from low to high includes it.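

In this assay, for the compounds shown here, compound 3 gives 1 nM as the only value in this set that is a number and not a limit. With hydrogen in place of 1-methylpyrrolidin-3-yl on the amide-type nitrogen, the simple carbamoyl compound keeps low-nanomolar inhibition, so the ring substituent is not required for a value at this level in this assay. The data give a number no lower from compound 2 to compound 3 (the limit leaves the size open) and a number no lower from compound 1 to compound 3 (the limit leaves the size open), and neither step can be read, their size staying open at this floor: the limit of < 1 nM in this assay, at which 2 of the 3 values shown sit.

Going by these compounds, how much the pyrrolidin-3-yl and 1-methylpyrrolidin-3-yl groups add, if anything, remains unknown. Also open, on these data alone, is how a plain methyl, a longer chain ending in an amine or a chain bearing a carboxylic acid on the amide nitrogen would read in this assay against compound 3.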